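Pyridin-4-yl for 4-cyanophenyl on a Sulfonamide Core

A few compounds are considered here, and "the series" means these few. Any claim that something is new, unique, unknown or untested is made for them only; others in the source may bear on it.

Measured so far:
compound 1, `COc1ccc(S(=O)(=O)N2CCc3cccc(NC(=O)c4ccc(C#N)cc4)c32)cc1` — 89 nM
compound 2, `COc1ccc(S(=O)(=O)N2CCc3cc(Br)cc(NC(=O)c4ccco4)c32)cc1` — 78 nM

Both compounds were tested in a functional assay on MKN-45 cells (Homo sapiens) for cytotoxicity; on this read-out lower numbers stand for stronger inhibition and higher numbers for weaker inhibition. Compound 1 gives 89 nM and compound 2 gives 78 nM. Of the two numbers, that of compound 1 is the higher, but the gap to compound 2 lies within the usual scatter, so the two cannot be told apart on this read-out. Going by the values given here, the two compounds also differ in more than one place, so no single step between them can be drawn.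

Compound 3, `COc1ccc(S(=O)(=O)N2CCc3cccc(NC(=O)c4ccncc4)c32)cc1`, has not yet been measured. It differs from compound 1 in one place: pyridin-4-yl in place of 4-cyanophenyl on a carbonyl carbon. Among the compounds with values here, no measured pair shows what this exchange does, so the size of the step is open. With compound 1 at 89 nM as the only anchor, the step of a 1.5-fold higher number from compound 1 to compound 3 (0.16 log units; within the scatter) is expected to be modest, possibly a slight weakening, but not far beyond the scatter. Compound 3 is therefore estimated at 130 nM, with a range from 40 nM to 450 nM.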

Compound 3, half-maximal inhibitory concentration: 8.8 nM
Estimate against measurement, compound 3: 15-fold (1.17 log units) above; measured number below the stated range.
By their numbers in this assay, from the lowest: compound 3; then compounds 2 and 1 (each within the scatter of the next).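

In this assay, going by these compounds alone, pyridin-4-yl in place of 4-cyanophenyl on a carbonyl carbon gives a 10-fold lower number from compound 1 to compound 3 (1.00 log units; beyond the scatter), the first step that can be read from a change in one place. It shows that this position, on a carbonyl carbon whose other neighbour is an amide-type nitrogen, is sensitive to the identity of the aromatic ring, even though both groups have the same counts of hydrogen-bond donors and acceptors and neither carries a net charge. Nothing measured here bears on why the number falls.

This single exchange removes the nitrile and places a hetero atom in the ring at the same time, so the compounds shown cannot separate the two changes, and a plain phenyl or a pyridin-3-yl on the same carbonyl carbon would be needed to tell them apart. Going by these compounds, it also remains open whether the same exchange would give a step of similar size on a core carrying bromine, as in compound 2, or with a furan-2-yl group replaced by pyridin-4-yl there.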